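Moving a hydroxyl on a curcuminoid: solubility in a new core

The compounds below may be only part of what the source reports. "The series", "measured", "known", "first", "only" and "open" are said of these compounds alone.

Measured so far:
compound 1 `O=C(/C=C/c1ccccc1O)CC(=O)/C=C/c1cccc(O)c1O` gives 11000 nM
compound 2 `O=C(/C=C/c1cccc(O)c1)CC(=O)/C=C/c1cccc(O)c1O` gives 8200 nM
compound 3 `O=C(/C=C/c1ccccc1O)CC(=O)c1ccc(O)c(O)c1` gives 77000 nM

The read-out in every case is a physicochemical assay for solubility, using the shake flask method, with a stated time of 12 h; on this read-out higher numbers stand for higher solubility and lower numbers for lower solubility. Among the three measured compounds, compound 3 gives the highest number, and its gaps to compound 1 and to compound 2 both lie beyond the usual scatter of repeated measurements. No counted difference between compound 3 and compound 1 is given, so the difference between the two cores is not broken down here.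

One change recurs. From compound 1 to compound 2 the change is 3-hydroxyphenyl in place of 2-hydroxyphenyl on a double-bonded chain carbon bound to a double-bonded chain carbon, and the step it made is a 1.3-fold lower number from compound 1 to compound 2 (0.13 log units; within the scatter), a shift that lies within the scatter and so signals no real movement in solubility.

Compound 4 `O=C(/C=C/c1cccc(O)c1)CC(=O)c1ccc(O)c(O)c1` has not yet been measured in this assay. It is related to compound 3 by the same change, (3-hydroxyphenyl in place of 2-hydroxyphenyl on a double-bonded chain carbon bound to a double-bonded chain carbon), made on the same kind of place, with compound 3 supplying the other core. Because the earlier instance gave only a 1.3-fold lower number from compound 1 to compound 2 (0.13 log units; within the scatter), the step from compound 3 to compound 4 is expected to be small as well, near a 1.2-fold lower number from compound 3 to compound 4 (0.09 log units; within the scatter). On that basis compound 4 is estimated to give 62000 nM in this assay, with a plausible range running from 30000 nM to 130000 nM.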

Compound 4, solubility: 25000 nM
The estimate for compound 4 lay 2.5-fold (0.39 log units) above the measured number; measured number outside the range, below it.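

In this assay, putting 3-hydroxyphenyl in place of 2-hydroxyphenyl on a double-bonded chain carbon bound to a double-bonded chain carbon gave a 3.1-fold lower number from compound 3 to compound 4 (0.49 log units; beyond the scatter), while the same change on the core of compound 1 had given a 1.3-fold lower number from compound 1 to compound 2 (0.13 log units; within the scatter). The change therefore did not carry over as a silent swap: the step that could not be told from noise on the core of compound 1 became a real, modest drop on the core of compound 3, so a near-zero step on one core did not predict a near-zero step on the other in this series. These two instances show only that the size of the step can differ with the core, not that one core will always respond more strongly, and no measurement shown here offers an explanation for the difference.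

The compounds shown leave open whether the change would give a small step or a real drop on any further core, since only two cores carry it here. They also leave open how the solubility would respond if an amine or a carboxylic acid stood in place of the hydroxyl on that phenyl ring.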